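Methyl to Chloro Swapped on Two Different Cores

The source may report more compounds than this note shows. Statements on the series, on what has been measured and on what is new or still open speak of the compounds shown alone.

Of the compounds shown here, three have so far been tested in a functional assay on MCF7 cells (Homo sapiens) for inhibition, read by MTT assay, with a stated time of 24 h; a lower number here means a stronger inhibitor, a higher number a weaker inhibitor. Compound 1, `Cc1ccc(NC(=O)COc2nc3ccccc3nc2/C=C\c2ccncc2)cc1`, gives 60200 nM. Compound 2, `O=C(COc1nc2ccccc2nc1/C=C\c1ccncc1)Nc1ccc(Cl)cc1`, reaches only the limit of the measurement, > 100000 nM. The change from compound 1 to compound 2 is chloro in place of methyl on an aromatic carbon, and it made an at least 1.6-fold higher number from compound 1 to compound 2 (0.22 log units; that floor lies within the scatter). Compound 3, `Cc1ccc(C(=O)Nc2ccc(Cn3c(=O)c(C)nc4ccccc43)cc2)cc1`, is built on a different core, and the difference between the two cores is not broken down here. Compound 3 also sits at a limit, > 100000 nM. Two of the three values thus share (the limit of > 100000 nM in this assay, at which 2 of the 3 values shown sit).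

Compound 4, `Cc1nc2ccccc2n(Cc2ccc(NC(=O)c3ccc(Cl)cc3)cc2)c1=O`, has not yet been measured. Going by the values given here, its difference from compound 3 is chloro in place of methyl on an aromatic carbon, which is the same change as the one between compound 1 and compound 2, made in the same kind of place. The earlier step pointed toward a higher number, although its floor lies within the usual scatter of this measurement, so it gives no firm direction on its own. Compound 3 already sits at the limit. Compound 4 is therefore expected to remain at that limit as well, with an expected step that the limit leaves unreadable from compound 3 to compound 4. The estimated value for compound 4 is 150000 nM, within an expected range from 60000 nM to 400000 nM, and the measurement is most likely to report only a limit once more.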

Compound 4, half-maximal inhibitory concentration: 47600 nM
Estimate against measurement, compound 4: 3.2-fold (0.50 log units) above; the measured number lies below the stated range.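

In this assay, chloro in place of methyl, on an aromatic carbon para to a large group, gives an at least 2.1-fold lower number from compound 3 to compound 4 (0.32 log units; beyond the scatter), and this step is known only as a floor, as it starts from a limit of the assay rather than a true number. Set beside the same swap on the other core, the step does not carry over, and the two results clearly differ: the same change on two cores in this assay, an at least 1.6-fold higher number (0.22 log units; that floor lies within the scatter) from compound 1 to compound 2 and an at least 2.1-fold lower number (0.32 log units; beyond the scatter) from compound 3 to compound 4, at least 3.4-fold (0.54 log units) apart, beyond the scatter of two such steps This shows that the effect of the swap on one core could not be used to predict its effect on the other, but two pairs make no general rule, and the data show neither the true size of either step nor the reason the cores part ways, with much of the picture cut off at the top of the scale: the limit of > 100000 nM in this assay, at which 2 of the 4 values shown sit.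

On these data alone, what stays open is whether the two cores would also respond differently to other groups at the same place, such as fluoro, methoxy or an amine. As far as these compounds go, it is also open how the swap would behave on a core where both members of the pair give true numbers, so that the full size of each step could be read.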